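The source may hold more compounds than are shown below. What is called first, only, known or untested is meant among the compounds shown, and "the series" means these compounds.

Measured so far:
Compound 1, `COc1cc(N)c(Cl)cc1NC(=O)C1CCN(Cc2cccc(C)c2)CC1`: in a functional assay on the whole organism for antagonist activity, with Mus musculus as the target (on this read-out lower numbers stand for an effect already at smaller amounts and higher numbers for an effect only at larger amounts of compound), compound 1 gives 2.4 mg/kg.
Compound 2, `CCCCN1CCC(C(=O)Nc2cc(Cl)c(N)cc2OC)CC1`: compound 2 reaches only a limit of the assay, > 10 mg/kg, in this assay, not a number.

Among the compounds with values here, compound 1 is thus the only member of the pair with a number in this assay; the other value is a bound, (the limit of > 10 mg/kg in this assay, at which 1 of the 2 values shown sits). Within the data shown here, the single measured step, an at least 4.1-fold higher number from compound 1 to compound 2 (0.61 log units; beyond the scatter), runs toward that bound and lies beyond the scatter; that step put propyl in place of 3-methylphenyl on a saturated chain carbon bound to an amine nitrogen in a ring.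

Compound 3, `COc1cc(N)c(Cl)cc1NC(=O)C1CCN(Cc2ccccc2F)CC1`, is not yet measured. It differs from compound 1 by 2-fluorophenyl in place of 3-methylphenyl on a saturated chain carbon bound to an amine nitrogen in a ring. The measured step bears on it only loosely: compound 3 keeps one six-membered aromatic ring of carbon only at that place, where compound 2 carries propyl. A change smaller than the step from compound 1 to compound 2 is therefore expected in this assay, plausibly within the scatter, with a slight lean toward higher numbers. Compound 3 is estimated at 3.5 mg/kg in this assay, with a range from 1.5 mg/kg to 9 mg/kg. The expected step is a 1.5-fold higher number from compound 1 to compound 3 (0.16 log units; within the scatter).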

Compound 3, dose for half-maximal effect: > 4 mg/kg
Compound 3 gave a limit, no number (the forecaster's own chance of this, stated with the estimate: 20%); at least 1.1-fold (0.05 log units) between middle value and limit.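

In this assay compound 3 gives no number, only a limit of the assay: the limit of > 4 mg/kg in this assay, at which 1 of the 3 values shown sits.

Within the data shown here, the only readable comparison is an at least 1.6-fold higher number from compound 1 to compound 3 (0.22 log units; that floor lies within the scatter), so 2-fluorophenyl in place of 3-methylphenyl on a saturated chain carbon bound to an amine nitrogen in a ring cannot yet be placed beyond the scatter, while the true size of the step stays open upward. What is new is that keeping one six-membered aromatic ring of carbon only at this place does not by itself give a number in this series: compound 3 keeps such a ring, as compound 1 does, yet ends at a limit, as compound 2 with propyl does.

The step between compound 2 and compound 3 cannot be read, as both values are limits, and compound 3 may lie close to compound 1 or far from it. The compounds shown also do not separate the identity of the ring substituent from its place on the ring, a question that 2-methylphenyl or 3-fluorophenyl at this same place would address, with unsubstituted phenyl as the plain reference.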